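What happens when the nitro group leaves compound 2?

This account rests on a few compounds, and the source may have more. Where it says the series, first, only, none or still open, it means among the compounds named here.

Measured in a functional assay, read by spectrophotometry, with a stated time of 3 min; on this read-out higher numbers stand for weaker inhibition and lower numbers for stronger inhibition:
Compound 1 `Nc1ccccc1/N=C\c1cc(=O)oc2cc(OCc3ccccc3)ccc12` gives 9250 nM
Compound 2 `O=c1cc(/C=N\Nc2ccc([N+](=O)[O-])cc2)c2ccc(OCc3ccccc3)cc2o1` gives 9510 nM

For the measured compounds named here, on these numbers, compound 2 cannot be told apart from compound 1, the only other compound measured. Compound 3 `O=c1cc(/C=N\Nc2ccccc2)c2ccc(OCc3ccccc3)cc2o1` differs from compound 2 by one change (hydrogen in place of nitro on an aromatic carbon), hydrogen in place of nitro on an aromatic carbon. Going by the values given here, no measured step makes this exact change. Among the compounds with values here, the nearest evidence is the one step available, a 1.0-fold higher number from compound 1 to compound 2 (0.01 log units; within the scatter), which alters the same part of the molecule and stays within the scatter. In this assay, no step beyond the scatter is therefore expected. The estimated step is a 1.0-fold lower number from compound 2 to compound 3 (0.01 log units; within the scatter), with no direction expected. Compound 3 is expected at 9400 nM (estimated range 4500 nM to 20000 nM).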

Compound 3, half-maximal inhibitory concentration: 13200 nM
Compound 3: the middle estimate sits 1.4-fold (0.15 log units) below what was measured; low and high end bracket the measured number.
By their numbers in this assay, from the lowest: compounds 1, 2 and 3 (each within the scatter of the next).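

In this assay, hydrogen in place of nitro on the aromatic ring gives a 1.4-fold higher number from compound 2 to compound 3 (0.14 log units; within the scatter) and so leaves the two compounds indistinguishable: at this position, the nitro group is not needed to hold the number at this level. Anilino in place of 2-aminophenyl gives a 1.4-fold higher number from compound 1 to compound 3 (0.15 log units; within the scatter) and likewise separates nothing. Nothing measured here explains this flat result. Going by these compounds, whether a chlorine atom, a methoxy group or a carboxylic acid at this place would move the number beyond the scatter stays open.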